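Compound 2 and the step to compound 4

A few compounds are considered here, and "the series" means these few. Any claim that something is new, unique, unknown or untested is made for them only; others in the source may bear on it.

Measured in a functional assay on SGC-7901 cells (Homo sapiens) for antiproliferative activity, read by MTT assay, with a stated time of 24 h; on this read-out lower numbers stand for stronger inhibition and higher numbers for weaker inhibition:
- Compound 1 `Cc1cccc(NNC(=O)c2ccc(NS(=O)(=O)c3cnc(O)nc3O)cc2)c1` gives > 20000 nM (a limit)
- Compound 2 `Cc1ccccc1NNC(=O)c1cccc(NS(=O)(=O)c2cnc(O)nc2O)c1` gives > 20000 nM (a limit)
- Compound 3 `O=C(NNC(=O)c1ccccc1Cl)c1ccc(NS(=O)(=O)c2cnc(O)nc2O)cc1` gives 3240 nM

Compound 2 has no number, only a limit, > 20000 nM. Compound 4 `Cc1ccc(C(=O)NNC(=O)c2cccc(NS(=O)(=O)c3cnc(O)nc3O)c2)cc1` carries (4-methylphenyl)carbonyl in place of 2-methylphenyl on an amine nitrogen, ((4-methylphenyl)carbonyl in place of 2-methylphenyl on an amine nitrogen). Going by the values given here, one measured step bears on this change, an at least 6.1-fold lower number from compound 1 to compound 3 (0.79 log units; beyond the scatter), with (2-chlorophenyl)carbonyl in place of 3-methylphenyl on an amine nitrogen. On these data alone, that step starts from a limit, so its full size is unknown, and it is a single case. A change of the same direction and similar size is expected here, namely an at least 4.0-fold lower number from compound 2 to compound 4 (0.60 log units; beyond the scatter) in this assay. For compound 4 the estimate is 5000 nM, with an expected range from 1500 nM to 18000 nM.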

Compound 4, half-maximal inhibitory concentration: 10100 nM
Compound 4: the middle estimate sits 2.0-fold (0.31 log units) below what was measured; measured number inside the range.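

On the core of compound 2, (4-methylphenyl)carbonyl on the amine nitrogen gives a measured number where 2-methylphenyl gave only a limit, adding a second case to the single earlier one. The step is an at least 1.9-fold lower number from compound 2 to compound 4 (0.29 log units; that floor lies within the scatter) and so does not by itself establish a real gain. Its full size stays unknown because it starts from a limit: the limit of > 20000 nM in this assay, at which 2 of the 4 values shown sit.

On these data alone, whether the carbonyl or the 4-methylphenyl ring carries the change remains open. So does the effect of an acetyl group or an amine-bearing chain at this nitrogen.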